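A Methyl Added to the Aromatic Ring of Compound 1

A few compounds are considered here, and "the series" means these few. Any claim that something is new, unique, unknown or untested is made for them only; others in the source may bear on it.

Within the data shown here, in an assay on microsomes from liver for inhibition of 3-hydroxy-3-methylglutaryl-coenzyme A reductase (Sus scrofa), read by colorimetric assay (a lower number here means a stronger inhibitor, a higher number a weaker inhibitor), compound 1 `CC(C)=CCC/C(C)=C/CCC1=C[C@H](c2ccccc2)OC1=O` gives 16500 nM, the lowest of the two numbers so far, and its nearest neighbour is compound 2 `CC(C)=CCC/C(C)=C/CCC1=C[C@H](c2ccccc2[N+](=O)[O-])OC1=O`, which in this assay gives 18900 nM. Among the measured compounds shown here, the single measured step, a 1.1-fold higher number from compound 1 to compound 2 (0.06 log units; within the scatter), bears on the change to compound 3 `CC(C)=CCC/C(C)=C/CCC1=C[C@H](c2ccc(C)cc2)OC1=O`: methyl in place of hydrogen on an aromatic carbon, para to a large group. One substitution on that ring left the number unchanged beyond the scatter, so for compound 3 another is expected to do the same, giving a 1.0-fold lower number from compound 1 to compound 3 (0.01 log units; within the scatter). Compound 3 is therefore estimated at 16000 nM, between 8000 nM and 33000 nM.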

Compound 3, half-maximal inhibitory concentration: 18100 nM
The estimate for compound 3 lay 1.1-fold (0.05 log units) below the measured number; measured number inside the range.
By their numbers in this assay, from the lowest: compounds 1, 3 and 2 (each within the scatter of the next).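

In this assay, methyl in place of hydrogen on the aromatic carbon para to a large group gives a step that stays within the scatter (a 1.1-fold higher number from compound 1 to compound 3 (0.04 log units; within the scatter)). Among these compounds, this is the first reading at this place on the ring, and it shows that phenyl to 4-methylphenyl leaves the number where it was. No available evidence explains this result.

The compounds shown leave open whether an amine, a carboxylic acid or a longer chain at this place would move the number beyond the scatter. They also leave open whether any change on this ring can do so.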